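Pyrrolidine-amide series: replacing the cyclopropyl side chain with pyridine

This account rests on a few compounds, and the source may have more. Where it says the series, first, only, none or still open, it means among the compounds named here.

Three compounds of the shared core carry measurements in a functional assay on a cell-free system (plasma, Homo sapiens), with a stated time of 3 min; a lower number here means a stronger inhibitor, a higher number a weaker inhibitor. Compound 1, `CC(C)(C)[C@@H](O)C(=O)N1[C@@H]2C[C@@H]2C[C@H]1C(=O)NCc1cc(Cl)ccc1-n1cnnn1`, gives 1100 nM. Compound 2, `CC1(C[C@@H](O)C(=O)N2C[C@H]3C[C@H]3[C@H]2C(=O)NCc2cc(Cl)ccc2-n2cnnn2)CC1`, gives 500 nM. Compound 3, `O=C(NCc1cc(Cl)ccc1-n1cnnn1)[C@@H]1CC=NN1C(=O)[C@H](O)C1CCCCC1`, gives 970 nM. Compound 2 shows the lowest of the three numbers; compound 3 sits within the scatter of it, while compound 1 lies beyond the scatter, so only the gap to compound 1 counts as a real difference. No pair of these compounds differs in a single place, so no single-change step is available as a guide.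

Compound 4, `O=C(NCc1cc(Cl)ccc1-n1cnnn1)[C@@H]1[C@@H]2C[C@@H]2CN1C(=O)[C@H](O)Cc1ccccn1`, has not yet been measured in this assay. It differs from compound 2 by pyridin-2-yl in place of 1-methylcyclopropyl on a saturated chain carbon, two bonds along the chain from a carbonyl carbon and an oxygen on a saturated carbon. The three measured values all fall inside a narrow band, and nothing among them speaks to the effect of an aromatic ring with a hydrogen-bond acceptor at this place. The step from compound 2 to compound 4 is therefore expected to be small, with no direction assigned, and estimated as a 1.2-fold higher number from compound 2 to compound 4 (0.08 log units; within the scatter). For compound 4 the expected value in this assay is 600 nM, with a range from 200 nM to 2000 nM.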

Compound 4, half-maximal inhibitory concentration: 1700 nM
Compound 4: the middle estimate sits 2.8-fold (0.45 log units) below what was measured; low and high end bracket the measured number.
By their numbers in this assay, from the lowest: compounds 2, 3, 1 and 4 (each within the scatter of the next, the first and the last beyond it).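

In this assay, among the compounds shown here, the exchange of 1-methylcyclopropyl for pyridin-2-yl gives a 3.4-fold higher number from compound 2 to compound 4 (0.53 log units; beyond the scatter) and is the one single-change step read so far. This position on the saturated chain carbon, two bonds along the chain from a carbonyl carbon and an oxygen on a saturated carbon, therefore does not tolerate every group equally: the larger six-membered aromatic ring with its hydrogen-bond acceptor goes with the higher number. Nothing at hand bears on which feature of the exchange lies behind the step.

From the compounds shown here alone, whether the higher number goes with the aromatic ring as such or with its ring nitrogen remains open, and phenyl at this place would be the direct comparison. Going by these compounds, how a primary amine on the same chain carbon would read also remains open.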